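Benzylamine Sulfonamides in a Capan-2 Growth Assay

The compounds below may be only part of what the source reports. "The series", "measured", "known", "first", "only" and "open" are said of these compounds alone.

Compound 1, `CC(C)(C)c1ccc(CNCCNS(=O)(=O)c2cc(C(F)(F)F)cc(C(F)(F)F)c2)cc1`: 13000 nM
Compound 2, `O=S(=O)(NCCCNCc1cccc(Cl)c1)c1cc(C(F)(F)F)cc(C(F)(F)F)c1`: 8000 nM
Compound 3, `O=S(=O)(NCCNCc1cccc2ccccc12)c1cc(C(F)(F)F)cc(C(F)(F)F)c1`: 21000 nM

These three compounds were measured in a functional assay on Capan-2 cells (Homo sapiens) for inhibition, read by MTT assay, with a stated time of 72 h; on this read-out lower numbers stand for stronger inhibition of growth and higher numbers for weaker inhibition of growth. Compound 2 has the lowest of the three numbers; its gap to compound 1 lies within the scatter, while compound 3 sits beyond it. Among the measured compounds shown here, the only single-site step among them, a 1.6-fold higher number from compound 1 to compound 3 (0.21 log units; within the scatter), exchanges the aryl group on a saturated chain carbon bound to an amine nitrogen and stays within the scatter. Compound 4, `COc1ccccc1CNCCCNS(=O)(=O)c1cc(C(F)(F)F)cc(C(F)(F)F)c1`, differs from compound 2 by 2-methoxyphenyl in place of 3-chlorophenyl on a saturated chain carbon bound to an amine nitrogen. For the measured compounds named here, because a 1.6-fold higher number from compound 1 to compound 3 (0.21 log units; within the scatter) is the one comparable change and was small, the expected step is a 1.3-fold higher number from compound 2 to compound 4 (0.10 log units; within the scatter), not beyond the scatter. Compound 4 is therefore estimated at 10000 nM, with a range from 4000 nM to 25000 nM.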

Compound 4, concentration for 50% growth inhibition: 6000 nM
Beside the measured number, compound 4's estimate is 1.7-fold (0.22 log units) above it; measured number inside the range.
By their numbers in this assay, from the lowest: compounds 4, 2, 1 and 3 (each within the scatter of the next, the first and the last beyond it).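

In this assay, the exchange on a saturated chain carbon bound to an amine nitrogen gives a 1.3-fold lower number from compound 2 to compound 4 (0.12 log units; within the scatter), so a substituted phenyl carrying one hydrogen-bond acceptor can replace 3-chlorophenyl here with no change beyond the scatter. This is a second aryl exchange at this place within the scatter, alongside a 1.6-fold higher number from compound 1 to compound 3 (0.21 log units; within the scatter) on the other chain. No measurement offered here accounts for this. Still open, from the compounds shown here alone, is whether a cyclohexyl group or a pyridine ring at this place would leave the number within the scatter. Also open, going by these compounds, is whether a carboxylic acid on the ring would do so.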